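The source may hold more compounds than are shown below. What is called first, only, known or untested is meant among the compounds shown, and "the series" means these compounds.

Measured compounds:
Compound 1 `CCNC(=O)c1cc(Oc2ccc(NC(=O)c3cc4cccnc4n(-c4ccc(F)cc4)c3=O)cc2)ccn1` — 1130 nM
Compound 2 `CCNC(=O)c1cc(Oc2ccc(NC(=O)c3cc4cccnc4n(-c4ccc(F)c(Cl)c4)c3=O)cc2)ccn1` — "not determined" (no result reported)

In a functional assay on U-87MG ATCC cells for antiproliferative activity against U-87 MG (Homo sapiens), read by MTT assay, with a stated time of 72 h (on this read-out higher numbers stand for weaker inhibition and lower numbers for stronger inhibition), compound 1 gives 1130 nM. Within the data shown here, this is the only number in the set: compound 2 carries no value, so compound 1 stands alone, and nothing can be said about how the two compare. Among the measured compounds shown here, no step between measured compounds is available.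

Compound 3 `CCCNC(=O)c1cc(Oc2ccc(NC(=O)c3cc4cccnc4n(-c4ccc(F)cc4)c3=O)cc2)ccn1` differs from compound 1 by methyl in place of hydrogen on a saturated chain carbon, two bonds along the chain from an amide-type nitrogen. For the measured compounds named here, nothing among the measured compounds bears on such a change. The expectation for the step from compound 1 to compound 3 is therefore for no move beyond the usual scatter, with direction left open; the expected step is a 1.0-fold lower number from compound 1 to compound 3 (0.01 log units; within the scatter).

Compound 3 is expected to give about 1100 nM in this assay, estimated to fall between 450 nM and 2800 nM.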

Compound 3, half-maximal inhibitory concentration: 960 nM
For compound 3 the middle estimate is 1.1-fold (0.06 log units) above the measured one, within the range that was stated.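

In this assay the change from ethylamino to propylamino gives a 1.2-fold lower number from compound 1 to compound 3 (0.07 log units; within the scatter), so this one pair shows that the read-out does not separate the two chains. Before this result, the set held no comparison at all, and nothing was known about any change on the saturated chain carbon, two bonds along the chain from an amide-type nitrogen; now one such change has been read, and methyl in place of hydrogen there leaves the number within the scatter. No measured evidence accompanies this result to speak to why it falls as it does.

The compounds shown leave open whether a longer chain such as butyl, a branched isopropyl group, or a chain ending in an amine or a carboxylic acid would stay within the scatter of compound 1. Going by these compounds, all of this rests on a single pair on one core, so it remains unknown whether the same change would read alike on a different core.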